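Ribose-bearing bicyclic series: three limits and one open compound

This account rests on a few compounds, and the source may have more. Where it says the series, first, only, none or still open, it means among the compounds named here.

Measured compounds in this assay:
compound 1 `C#Cc1cn([C@@H]2O[C@H](CO)[C@@H](O)[C@H]2O)c2ncnc(C)c12` — > 20000 nM
compound 2 `C#Cc1cn([C@@H]2O[C@H](CO)[C@@H](O)[C@H]2O)c2ncnc(NC)c12` — > 20000 nM
compound 3 `CNc1ncnc2c1c(-c1ccsc1)cn2[C@@H]1O[C@H](CO)[C@@H](O)[C@H]1O` — > 20000 nM

All three values are limits of a functional assay on HCT-116 cells (Homo sapiens), read by MTT assay, with a stated time of 72 h (a lower number here means a stronger inhibitor, a higher number a weaker inhibitor), not numbers. The step that the two limits leave unreadable from compound 2 to compound 1 is the change (methyl in place of methylamino on an aromatic carbon). The step that the two limits leave unreadable from compound 2 to compound 3 is the change (thiophen-3-yl in place of ethynyl on an aromatic carbon), which is how the cores of compound 2 and compound 3 differ. Neither step can be sized because of the limit of > 20000 nM in this assay, at which 3 of the 3 values shown sit.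

Compound 4 `Cc1ncnc2c1c(-c1ccsc1)cn2[C@@H]1O[C@H](CO)[C@@H](O)[C@H]1O` arises from compound 3 by methyl in place of methylamino on an aromatic carbon, the same change as from compound 2 to compound 1, at a place described in the same words. The step expected here is a step that the limit leaves unreadable from compound 3 to compound 4. This rests on compound 1, whose value > 20000 nM is a limit. For compound 4 the expected value in this assay is 30000 nM, between 15000 nM and 100000 nM, and most likely the assay again reports only a limit.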

Compound 4, half-maximal inhibitory concentration: 460 nM
For compound 4 the middle estimate is 65-fold (1.81 log units) above the measured one; measured number outside the range, below it.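

In this assay, methyl in place of methylamino gives an at least 43-fold lower number from compound 3 to compound 4 (1.63 log units; beyond the scatter), and with methyl held fixed, thiophen-3-yl in place of ethynyl gives an at least 43-fold lower number from compound 1 to compound 4 (1.63 log units; beyond the scatter). The change from methylamino to methyl therefore has a readable effect on the core bearing thiophen-3-yl, and compound 4 is the only compound shown with a number rather than a limit. Whether the change has any effect on the core bearing ethynyl stays unknown, because the steps among the other compounds cannot be read: the limit of > 20000 nM in this assay, at which 3 of the 4 values shown sit.

Still open, from the compounds shown here alone, is whether ethyl in place of methyl keeps the value of compound 4. Also open, going by these compounds, is whether phenyl or furan-3-yl can stand in place of thiophen-3-yl.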